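Fluoro to nitro: what the measured steps suggest

The source may hold more compounds than are shown below. What is called first, only, known or untested is meant among the compounds shown, and "the series" means these compounds.

Of the compounds shown here, three that share one core have been measured in a functional assay on A549 cells (Homo sapiens) for antiproliferative activity, read by MTT assay, with a stated time of 72 h; a higher number here means a weaker inhibitor, a lower number a stronger inhibitor. Compound 3 `COc1cc(-n2cnc3ccc(-c4cccc(F)c4)cc32)cc(OC)c1OC`, carrying a 3-fluorophenyl, gives 5270 nM. Compound 2 `COc1cc(-n2cnc3ccc(-c4ccc(C(F)(F)F)cc4)cc32)cc(OC)c1OC`, carrying a 4-(trifluoromethyl)phenyl, gives 3390 nM. The step of a 1.6-fold higher number from compound 2 to compound 3 (0.19 log units; within the scatter) leaves these two level with each other. Compound 1 `COc1cc(-n2cnc3ccc(-c4ccccc4Cl)cc32)cc(OC)c1OC`, carrying a 2-chlorophenyl, gives > 10000 nM, which is a limit and not a number. The step of an at least 2.9-fold lower number from compound 1 to compound 2 (0.46 log units; beyond the scatter) goes beyond the scatter, whereas the floor of an at least 1.8-fold lower number from compound 1 to compound 3 (0.27 log units; that floor lies within the scatter) does not.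

Compound 4 `COc1cc(-n2cnc3ccc(-c4cccc([N+](=O)[O-])c4)cc32)cc(OC)c1OC` differs from compound 3 in one place: nitro in place of fluoro on an aromatic carbon. For the measured compounds named here, no measured step makes this exact swap, so the nearest guide is the change of aryl group in the other steps. Going by the values given here, the only one joining two true numbers, a 1.6-fold higher number from compound 2 to compound 3 (0.19 log units; within the scatter), stays within the scatter, so no step beyond the scatter is expected in this assay. The estimated step is a 1.1-fold lower number from compound 3 to compound 4 (0.02 log units; within the scatter). For compound 4 the expected value is 5000 nM, with an estimated range of 2000 nM to 10000 nM.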

Compound 4, half-maximal inhibitory concentration: 5410 nM
Compound 4: the middle estimate sits 1.1-fold (0.03 log units) below what was measured, and the stated range covers the measured number.
By their numbers in this assay, from the lowest: compounds 2, 3 and 4 (each within the scatter of the next). At a limit, above all of these: compound 1.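

In this assay, nitro, with 3 heavy atoms and 2 hydrogen-bond acceptors, replaces fluoro, with 1 heavy atom and none, on a carbon meta to a large group, and the result is a 1.0-fold higher number from compound 3 to compound 4 (0.01 log units; within the scatter), so this assay does not separate the two groups at this position. The 3-nitrophenyl also stays level with the 4-(trifluoromethyl)phenyl, with a 1.6-fold higher number from compound 2 to compound 4 (0.20 log units; within the scatter). Compound 1 stands at a limit and not at a number, so an at least 1.8-fold lower number from compound 1 to compound 4 (0.26 log units; that floor lies within the scatter) gives only a floor: the limit of > 10000 nM in this assay, at which 1 of the 4 values shown sits.

As far as these compounds go, it remains open whether any group on this carbon can move the number beyond the scatter, and an amine or a carboxylic acid there would test that. From the compounds shown here alone, the true number for compound 1 also stays open, and with it whether the 2-chlorophenyl really differs from the 3-nitrophenyl.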